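Sulfonyl substituent and passive permeability in the urea series

The compounds below may be only part of what the source reports. "The series", "measured", "known", "first", "only" and "open" are said of these compounds alone.

Measured compounds:
compound 1 `CC(C)(C)NC(=O)NCCS(=O)(=O)NC(=O)c1ccc(Nc2nc(NC3(c4ccc(Cl)cc4)CC3)nc(OCC(F)(F)F)n2)cc1` gives 49 nm/s in a physicochemical assay for permeability, using PAMPA, at pH 7.4; on this read-out lower numbers stand for lower permeability and higher numbers for higher permeability
compound 2 `O=C(NS(=O)(=O)c1ccccc1)c1ccc(Nc2nc(NC3(c4ccc(Cl)cc4)CC3)nc(OCC(F)(F)F)n2)cc1` gives 182 nm/s in this assay

For the measured compounds named here, compound 2 stands highest of the two numbers in this assay; the only measured step is a 3.7-fold higher number from compound 1 to compound 2 (0.57 log units; beyond the scatter). Compound 3 `CNC(=O)NCCS(=O)(=O)NC(=O)c1ccc(Nc2nc(NC3(c4ccc(Cl)cc4)CC3)nc(OCC(F)(F)F)n2)cc1` has not yet been measured in this assay. Its change from compound 2 is 2-((methylcarbamoyl)amino)ethyl in place of phenyl on a sulfonyl sulfur. Going by the values given here, this reverses the one measured step, with a smaller alkyl on the urea nitrogen, so a drop beyond the scatter is expected: the estimated step is a 5.2-fold lower number from compound 2 to compound 3 (0.72 log units; beyond the scatter). For compound 3 the estimate in this assay is 35 nm/s, with a range from 12 nm/s to 100 nm/s.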

Compound 3, apparent permeability: 40 nm/s
Compound 3: middle estimate off by 1.1-fold (0.06 log units), on the low side, and the stated range covers the measured number.
By their numbers in this assay, from the lowest: compounds 3 and 1 (each within the scatter of the next); then compound 2.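

In this assay, the step is a 1.2-fold lower number from compound 1 to compound 3 (0.09 log units; within the scatter) for methyl in place of tert-butyl on an amide-type nitrogen, so these two urea end groups read alike. A second urea chain in place of phenyl on the sulfonyl sulfur gives a 4.6-fold lower number from compound 2 to compound 3 (0.66 log units; beyond the scatter) and so shows that the gap to compound 2 is not confined to compound 1. No measurement on hand gives a cause for either step.

Left open is whether the urea or the chain beneath it sets this level. A plain alkyl chain, an amine, a carboxylic acid or a longer chain on the sulfonyl sulfur would tell these apart.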